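Ortho substituent swap on the anilino ring: chloro to hydroxy

The source may report more compounds than this note shows. Statements on the series, on what has been measured and on what is new or still open speak of the compounds shown alone.

Measured compounds in a functional assay on ECa-109 cells (Homo sapiens) for inhibition, read by MTT assay, with a stated time of 72 h; a higher number here means a weaker inhibitor, a lower number a stronger inhibitor:
compound 1, `CC(C)c1ccc(-c2nc(SCc3cn(CC(=O)NC(=O)Nc4ccccn4)nn3)nc(Nc3ccccc3Cl)c2C#N)cc1`, 23400 nM
compound 2, `CC(C)c1ccc(-c2nc(SCc3cn(CC(=O)NC(=O)Nc4ccccn4)nn3)nc(Nc3ccccc3)c2C#N)cc1`, > 64000 nM, which is a limit of the assay
compound 3, `Cc1ccccc1Nc1nc(SCc2cn(CC(=O)NC(=O)Nc3ccccn3)nn2)nc(-c2ccc(C(C)C)cc2)c1C#N`, 7230 nM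

Compound 1 holds the highest of the two numbers shown; compound 3 stands nearest, and compound 2 reaches only (the limit of > 64000 nM in this assay, at which 1 of the 3 values shown sits).

Compound 4, `CC(C)c1ccc(-c2nc(SCc3cn(CC(=O)NC(=O)Nc4ccccn4)nn3)nc(Nc3ccccc3O)c2C#N)cc1`, differs from compound 1 by hydroxy in place of chloro on an aromatic carbon. Two measured steps start from the same ring position: an at least 2.7-fold higher number from compound 1 to compound 2 (0.43 log units; beyond the scatter) and a 3.2-fold lower number from compound 1 to compound 3 (0.51 log units; beyond the scatter). Removing chloro raised the number, methyl lowered it; neither step involves a hydroxy, so the direction for compound 4 is not settled, and a step of modest size either way is plausible.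

For compound 4 the expected value is 30000 nM, with a range of 8000 nM to 64000 nM. This estimate corresponds to a 1.3-fold higher number from compound 1 to compound 4 (0.11 log units; within the scatter).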

Compound 4, half-maximal inhibitory concentration: 7380 nM
Beside the measured number, compound 4's estimate is 4.1-fold (0.61 log units) above it, outside the stated range (below it).
By their numbers in this assay, from the lowest: compounds 3 and 4 (each within the scatter of the next); then compound 1. At a limit, above all of these: compound 2.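

In this assay, hydroxy at this position, ortho to a large group, gives a 3.2-fold lower number from compound 1 to compound 4 (0.50 log units; beyond the scatter), and hydroxy and methyl are not told apart here: a 1.0-fold higher number from compound 3 to compound 4 (0.01 log units; within the scatter). Set against hydrogen, hydroxy gives an at least 8.6-fold lower number from compound 2 to compound 4 (0.93 log units; beyond the scatter), so two different groups at this position now read alike, and both lower the number relative to chloro. The value of compound 2 is a limit, not a number: the limit of > 64000 nM in this assay, at which 1 of the 4 values shown sits.

As far as these compounds go, it remains open whether methoxy, an amine or fluoro at this position would read like hydroxy and methyl. From the compounds shown here alone, it also remains open whether these groups behave alike at other positions of this ring.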